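The compounds below may be only part of what the source reports. "The series", "measured", "known", "first", "only" and "open" are said of these compounds alone.

Three measured compounds share one core and differ only at their outer ends. Compound 1 `COc1cc2ncnc(Nc3ccc(F)c(Cl)c3)c2cc1OCCn1ccnc1[N+](=O)[O-]` in a functional assay on HT-29 cells (Homo sapiens) for cytotoxicity, read by sulforhodamine B assay, with a stated time of 72 h (on this read-out lower numbers stand for stronger inhibition and higher numbers for weaker inhibition), gives 10000 nM. Compound 2 `COc1cc2ncnc(Nc3cccc(Br)c3)c2cc1OCCCn1ccnc1[N+](=O)[O-]` gives 4010 nM in this assay, and compound 3 `C#Cc1cccc(Nc2ncnc3cc(OC)c(OCCCn4ccnc4[N+](=O)[O-])cc23)c1` gives 5530 nM. Compound 1 stands with the highest number of the three: against compound 3 its value lies within the scatter, while against compound 2 it lies beyond it. Among the measured compounds shown here, the only step between compounds that differ in one place is a 1.4-fold higher number from compound 2 to compound 3 (0.14 log units; within the scatter), and that step concerns the bromo or ethynyl end of the molecule, not the chain carrying the 2-nitro-1H-imidazol-1-yl group.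

Compound 4 `COc1cc2ncnc(Nc3ccc(F)c(Cl)c3)c2cc1OCCCCn1c([N+](=O)[O-])cnc1C` has not yet been measured. It differs from compound 1 in 2-(2-methyl-5-nitro-1H-imidazol-1-yl)ethyl in place of 2-nitro-1H-imidazol-1-yl on a saturated chain carbon, two bonds along the chain from an oxygen on an aromatic ring. For the measured compounds named here, no measured step touches this chain or its ring, so the data give no direct guide to the size or the direction of the change. Going by the values given here, since the one measured step, between compounds 2 and 3, lay within the scatter, the step from compound 1 to compound 4 is expected to be small, no change at the digits printed from compound 1 to compound 4 (within the scatter), with no clear direction. The estimate for compound 4 is therefore 10000 nM, in a range from 3000 nM to 30000 nM.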

Compound 4, half-maximal inhibitory concentration: 9980 nM
Beside the measured number, compound 4's estimate is 1.0-fold (0.00 log units) above it; low and high end bracket the measured number.
By their numbers in this assay, from the lowest: compounds 2, 3, 4 and 1 (each within the scatter of the next, the first and the last beyond it).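

In this assay, the exchange at this saturated chain carbon, two bonds along the chain from an oxygen on an aromatic ring, gives a 1.0-fold lower number from compound 1 to compound 4 (0.00 log units; within the scatter), and this is the first step shown that touches the chain and its ring instead of the bromo or ethynyl end. For this one pair, replacing 2-nitro-1H-imidazol-1-yl, with 8 heavy atoms, by 2-(2-methyl-5-nitro-1H-imidazol-1-yl)ethyl, with 11 heavy atoms, therefore leaves the number unchanged within the scatter, so this place tolerates the larger group in this assay. No evidence is available to explain why the two groups read alike.

The exchange alters the chain and the ring together, so the pair cannot show what each alteration does alone, or whether two opposing effects cancel or neither has any effect. The compounds shown also leave open whether a group with no nitro on it, such as a plain 1H-imidazol-1-yl, an amine or a carboxylic acid, would read the same at the end of this chain, and whether the exchange would behave alike on the bromo or ethynyl compounds.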